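Inverting one chain stereocentre at an assay limit

The source may report more compounds than this note shows. Statements on the series, on what has been measured and on what is new or still open speak of the compounds shown alone.

Two entries frame the series in an ADME assay on a cell-free system (plasma, Mus musculus) for protein binding, using equilibrium dialysis, with a stated time of 5 h, tested at 10 uM; a higher number here means a larger unbound share of the compound, a lower number a smaller unbound share. For compound 1 `CC[C@@H](c1ccc(C(=O)O)c(Oc2cccc(Cl)c2)c1F)N1CCC[C@H](n2cc(C)c(=O)[nH]c2=O)C1`, the entry reads "not determined" (no result reported), so it offers no point of comparison. Compound 2 `Cc1cn([C@H]2CCCN([C@H](CC(C)C)c3ccc(C(=O)O)c(Oc4cccc(Cl)c4)c3F)C2)c(=O)[nH]c1=O` gives < 0.01, which is a limit of the assay and not a number. Within the data shown here, the only evidence on where compound 2 stands is therefore (the limit of < 0.01 in this assay, at which 1 of the 2 values shown sits).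

Compound 3 `Cc1cn([C@H]2CCCN([C@@H](CC(C)C)c3ccc(C(=O)O)c(Oc4cccc(Cl)c4)c3F)C2)c(=O)[nH]c1=O` is the next compound to be read: the two compounds have the same atoms and bonds and differ only in configuration as drawn: 1 of 2 stereo elements differ; a stereocentre at a saturated chain carbon is drawn R in compound 2 and S in compound 3. Among the measured compounds shown here, the inverted stereocentre at a saturated chain carbon is the only difference, and no measured pair shows what such an inversion does in this assay. The expectation for compound 3 rests on compound 2 alone, whose limit is < 0.01. No shift beyond the usual scatter is expected, no direction can be assigned, and a second limit would be no surprise. The expected size is a step that the limit leaves unreadable from compound 2 to compound 3. For compound 3 the estimated unbound fraction is 0.008, with an expected range from 0.003 to 0.02.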

Compound 3, unbound fraction: 0.005
Beside the measured number, compound 3's estimate is 1.6-fold (0.20 log units) above it; the measured number falls inside the stated range.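

No step can be read from compound 2 to compound 3 in this assay: the entry for compound 2 is a limit of the assay and not a number, so the stereocentre inversion at the saturated chain carbon has no readable size. The compounds shown leave open whether this inversion changes the unbound fraction, and in which direction.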